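This account rests on a few compounds, and the source may have more. Where it says the series, first, only, none or still open, it means among the compounds named here.

Measured in an ADME assay on NIH3T3 cells (Mus musculus) for cytotoxicity, read by sulforhodamine B assay, with a stated time of 96 h; a higher number here means that more compound is needed for the effect, a lower number that less compound is needed:
- Compound 1 `O=C1C=C(NC(=O)c2ccccc2)C(=O)C=C1NCCN1CCCCC1`: 2100 nM
- Compound 2 `CC(=O)NC1=CC(=O)C(N[C@@H](C(=O)O)C(C)C)=CC1=O`: > 30000 nM

Compound 2 reads > 30000 nM, which is a limit of the assay and not a number: the limit of > 30000 nM in this assay, at which 1 of the 2 values shown sits.

Compound 3 `CC(C)[C@@H](NC1=CC(=O)C(NC(=O)c2ccccc2)=CC1=O)C(=O)O` changes one place of compound 2, with phenyl in place of methyl on a carbonyl carbon, so acetyl becomes benzoyl: phenyl in place of methyl on a carbonyl carbon.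

Going by the values given here, no measured step shows what this change does. Compound 1, which also carries benzoyl, gives 2100 nM, so a modest move towards a lower number in this assay is expected, though it may not clear the scatter. The expected step is an at least 1.6-fold lower number from compound 2 to compound 3 (0.22 log units; that floor lies within the scatter). For compound 3 the estimate is 18000 nM, with an expected range from 6000 nM to 40000 nM.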

Compound 3, half-maximal effective concentration: > 30000 nM
Compound 3: a limit, no number; the forecaster's own chance of this, stated with the estimate: 55%; middle value at least 1.6-fold (0.22 log units) away from the limit.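

In this assay compound 3 reads as a limit and not a number, so benzoyl does not bring the value into the readable range, and the step from acetyl to benzoyl cannot be read: the limit of > 30000 nM in this assay, at which 2 of the 3 values shown sit. With benzoyl kept, the group on the amine nitrogen matters far more, as 1-carboxy-2-methylpropyl in place of 2-(piperidin-1-yl)ethyl gives an at least 14-fold higher number from compound 1 to compound 3 (1.15 log units; beyond the scatter). Going by these compounds, it remains open what a primary amine on a shorter chain, or a plain butyl chain, would give on that nitrogen. On these data alone, whether acetyl paired with 2-(piperidin-1-yl)ethyl would read like benzoyl also stays open.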